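The source may report more compounds than this note shows. Statements on the series, on what has been measured and on what is new or still open speak of the compounds shown alone.

The series shares one core: compound 1 `Cc1ccsc1-c1ccccc1NCC1=NCCN1` carries a 3-methylthiophen-2-yl group on an aromatic carbon, and in a functional assay for activation of Alpha-1D adrenergic receptor (Homo sapiens) (a higher number here means that more compound is needed for the effect, a lower number that less compound is needed), compound 1 gives 49 nM. Compound 2 `Cc1nc(-c2ccccc2NCC2=NCCN2)no1` carries a 5-methyl-1,2,4-oxadiazol-3-yl group in the same place. For compound 2 this assay reports only a limit, < 5020 nM, which is a limit of the assay and not a number. The step that the limit leaves unreadable from compound 1 to compound 2 therefore cannot be read, because of the limit of < 5020 nM in this assay, at which 1 of the 2 values shown sits.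

Compound 3 `CO/N=C(\C)c1ccccc1NCC1=NCCN1` differs from compound 2 by a group of 5 heavy atoms (3 carbon, 1 nitrogen, 1 oxygen; no ring) in place of a group of 6 heavy atoms (3 carbon, 2 nitrogen, 1 oxygen; one five-membered aromatic ring with 3 hetero atoms), on an aromatic carbon. For the measured compounds named here, no measured step bears on this change: the one step known is unreadable, and compound 2 itself has no number. The size and direction of the step from compound 2 to compound 3 in this assay are thus open. As a rough estimate, compound 3 is expected to give 600 nM, within 60 nM to 5000 nM, the step that the limit leaves unreadable from compound 2 to compound 3 being an estimate and nothing more.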

Compound 3, half-maximal effective concentration: < 5020 nM
Compound 3 gave a limit, no number; the forecaster's own chance of this, stated with the estimate: 30%; the middle value does not contradict the limit.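

Compound 3 gives < 5020 nM in this assay, which is a limit of the assay and not a number, so no step linking compound 3 to compound 1 or compound 2 can be read: the limit of < 5020 nM in this assay, at which 2 of the 3 values shown sit.

As far as these compounds go, how compound 2 and compound 3 truly compare with compound 1, and with each other, stays open.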